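The source may report more compounds than this note shows. Statements on the series, on what has been measured and on what is new or still open speak of the compounds shown alone.

Measured compounds:
Compound 1, `COc1cccc(NC2=CC(=O)c3nc4n(c3C2=O)[C@H]2OC[C@@H](O)[C@H]2OC4)c1`: 7620 nM
Compound 2, `O=C1C=C(Nc2ccc(C(F)(F)F)cc2)C(=O)c2c1nc1n2[C@H]2OC[C@@H](O)[C@H]2OC1`: 5500 nM
Compound 3, `CCOc1ccc(NC2=CC(=O)c3nc4n(c3C2=O)[C@H]2OC[C@@H](O)[C@H]2OC4)cc1`: 3210 nM

All three were read in a functional assay on ECa-109 cells for inhibition, with ECa-109 cell line (Homo sapiens) as the target, read by sulforhodamine B assay; on this read-out lower numbers stand for stronger inhibition and higher numbers for weaker inhibition. Compound 1 gives the highest number of the three. The closest of the other two is compound 2, and the step between them is a 1.4-fold lower number from compound 1 to compound 2 (0.14 log units; within the scatter). The furthest is compound 3, with a 2.4-fold lower number from compound 1 to compound 3 (0.38 log units; beyond the scatter). Between the other pair the step is a 1.7-fold lower number from compound 2 to compound 3 (0.23 log units; within the scatter).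

Compound 4, `CCCN(CCC)C1=CC(=O)c2nc3n(c2C1=O)[C@H]1OC[C@@H](O)[C@H]1OC3`, shares the core of compound 1 and differs from it in one place: dipropylamino in place of (3-methoxyphenyl)amino on a double-bonded ring carbon. None of the three measured steps bears closely on this change. Each of them swaps one substituted aromatic ring on the amine nitrogen for another, and the numbers moved only modestly or within the scatter. Going by the values given here, no measured step removes the aromatic ring or the hydrogen-bond donor, so the data give no direct guide to the size or direction of the step in this assay; the change is larger than any step seen so far, and a wide range is appropriate. Compound 4 is estimated to give 10000 nM, in a range from 3000 nM to 40000 nM. The expected step is a 1.3-fold higher number from compound 1 to compound 4 (0.12 log units; within the scatter).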

Compound 4, half-maximal inhibitory concentration: > 16000 nM
Compound 4 ended at the assay's limit; the forecaster's own chance of this, stated with the estimate: 15%; at least 1.6-fold (0.20 log units) between middle value and limit.
By their numbers in this assay, from the lowest: compounds 3, 2 and 1 (each within the scatter of the next, the first and the last beyond it). At a limit, above all of these: compound 4.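

In this assay compound 4 stands at a limit of the assay, not at a number: the limit of > 16000 nM in this assay, at which 1 of the 4 values shown sits. Putting dipropylamino in place of (3-methoxyphenyl)amino on the double-bonded ring carbon gives an at least 2.0-fold higher number from compound 1 to compound 4 (0.32 log units; beyond the scatter), and this is the first step shown that leads to a higher number from compound 1, whereas its steps to compound 2 and compound 3 both lead to lower numbers. The earlier compounds shown here all keep an aromatic ring and a hydrogen-bond donor on the amine nitrogen, so only compound 4 shows that inhibition on this read-out responds to a change of the whole group at this position, not just of the substituents on its aromatic ring.

Compound 4 loses the aromatic ring and the hydrogen-bond donor in a single change, so the compounds shown do not tell which of the two matters, and a propylamino or cyclohexylamino group at this position would bear on that question. From the compounds shown here alone, how far compound 4 lies past the limit also stays open, so the full size of this step is unknown.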